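Swapping the amine linker for sulfur on the shared core

The compounds below may be only part of what the source reports. "The series", "measured", "known", "first", "only" and "open" are said of these compounds alone.

In a functional assay on A549 cells (Homo sapiens) for inhibition, read by sulforhodamine B assay, with a stated time of 48 h (a lower number here means that less compound is tolerated, a higher number that more compound is tolerated), compound 2 `Nc1cc(N)c2nc(-c3ccccc3)c(NCc3ccc(F)cc3)nc2c1` gives 69200 nM, level with compound 1 `Nc1cc(N)c2nc(-c3ccccc3)c(NCc3ccc(Cl)c(Cl)c3)nc2c1`, which gives 69200 nM; the step of no change at the digits printed from compound 1 to compound 2 (within the scatter) lies within the scatter. Compound 3 `COc1ccc(CNc2nc3cc(N)cc(N)c3nc2-c2ccccc2)cc1` gives only a limit of this assay, < 100000 nM (the limit of < 100000 nM in this assay, at which 1 of the 3 values shown sits). That limit leaves the steps a step that the limit leaves unreadable from compound 1 to compound 3 and a step that the limit leaves unreadable from compound 2 to compound 3 unsized. Compound 4 `Nc1cc(N)c2nc(-c3ccccc3)c(Sc3ccc(F)cc3)nc2c1` differs from compound 2 by (4-fluorophenyl)sulfanyl in place of (4-fluorobenzyl)amino on an aromatic carbon. Within the data shown here, none of the measured steps touches this linker; all of them change the outer ring and none showed a readable shift, so no step beyond the scatter is expected here. The expected step is therefore no change at the digits printed from compound 2 to compound 4 (within the scatter). Compound 4 is estimated at 69200 nM, with a range from 25000 nM to 150000 nM.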

Compound 4, concentration lethal to 50% of the cells: 70800 nM
The estimate for compound 4 lay 1.0-fold (0.01 log units) below the measured number; measured number inside the range.
By their numbers in this assay, from the lowest: compounds 1, 2 and 4 (each within the scatter of the next).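

Among these compounds, until now only the outer ring had varied, and compound 4 is the first to alter the link itself on the aromatic carbon, giving in this assay a 1.0-fold higher number from compound 2 to compound 4 (0.01 log units; within the scatter). The (4-fluorophenyl)sulfanyl group has no hydrogen-bond donor, unlike (4-fluorobenzyl)amino, yet the two numbers lie within the scatter of each other. Nothing measured here accounts for this.

Open, from the compounds shown here alone, is whether a benzylsulfanyl group, which keeps the chain carbon, or a phenoxy group with an oxygen link would read the same. Going by these compounds, a sulfonyl link is equally open.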